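The compounds below may be only part of what the source reports. "The series", "measured", "known", "first", "only" and "open" are said of these compounds alone.

Three compounds have been measured in a functional assay on MGC-803 cells (Homo sapiens) for antiproliferative activity, read by MTT assay, with a stated time of 72 h; on this read-out higher numbers stand for weaker inhibition and lower numbers for stronger inhibition:

Compound 1 `O=C(NO)c1ccc(NCc2nc(-c3ccccc3)nn2-c2ccccc2Cl)cc1`: 9630 nM
Compound 2 `Cc1ccccc1-n1nc(-c2ccccc2)nc1CNc1ccc(C(=O)NO)cc1`: 12300 nM
Compound 3 `COc1ccc(-n2nc(-c3ccccc3)nc2CNc2ccc(C(=O)NO)cc2)cc1`: 7050 nM

Compound 3 gives the lowest of the three numbers, but the steps leading to it, a 1.4-fold lower number from compound 1 to compound 3 (0.14 log units; within the scatter) and a 1.7-fold lower number from compound 2 to compound 3 (0.24 log units; within the scatter), lie within the scatter, as does a 1.3-fold higher number from compound 1 to compound 2 (0.11 log units; within the scatter). Compound 4 `O=C(NO)c1ccc(NCc2nc(-c3ccccc3)nn2-c2ccc(Br)cc2)cc1` differs from compound 3 by bromo in place of methoxy on an aromatic carbon. All three measured steps change the same ring of the shared core as this one does, and none of them moved the number beyond the scatter, so for compound 4 no step beyond the scatter is expected in this assay. Compound 4 is therefore estimated at 8000 nM, with a range from 3500 nM to 18000 nM, meaning an expected step of a 1.1-fold higher number from compound 3 to compound 4 (0.05 log units; within the scatter).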

Compound 4, half-maximal inhibitory concentration: 9300 nM
Estimate against measurement, compound 4: 1.2-fold (0.07 log units) below; low and high end bracket the measured number.
By their numbers in this assay, from the lowest: compounds 3, 4, 1 and 2 (each within the scatter of the next).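

In this assay, bromo in place of methoxy gives a 1.3-fold higher number from compound 3 to compound 4 (0.12 log units; within the scatter) even though the entering group has one heavy atom and no hydrogen-bond acceptor, so removing the methoxy oxygen at this ring position left the number within the scatter. The 4-bromophenyl group also gives a 1.3-fold lower number from compound 2 to compound 4 (0.12 log units; within the scatter) and a 1.0-fold lower number from compound 1 to compound 4 (0.02 log units; within the scatter) and so stays within the scatter of both ortho-free comparisons' partners as printed. No measurement here offers an explanation for these small steps.

As far as these compounds go, whether an amine or a carboxylic acid at this ring position would move the number beyond the scatter remains open. The same holds for a longer chain such as butoxy.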